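The source may report more compounds than this note shows. Statements on the series, on what has been measured and on what is new or still open speak of the compounds shown alone.

Measured so far:
compound 1, `COc1ccc(C(CC/N=C(\N)NCCCc2c[nH]cn2)c2ccccn2)cc1`, in a functional assay on muscle tissue for agonist activity at histamine H2 receptor (Cavia porcellus); on this read-out higher numbers stand for higher potency (the scale is a negative logarithm) and lower numbers for lower potency: 7
compound 2, `N=C(NCCCc1c[nH]cn1)NCCC(c1ccc(F)cc1)c1ccccn1`, in this assay : 7.94

In this assay compound 2 gives the higher of the two values, with compound 1 a clear distance below it, beyond the scatter. Compound 3, `N=C(NCCCc1c[nH]cn1)NCCC(c1ccc(C(F)(F)F)cc1)c1ccccn1`, differs from compound 2 in one place: trifluoromethyl in place of fluoro on an aromatic carbon. For the measured compounds named here, no measured pair shows this change, so no step of known size can guide the estimate. The change is expected to bring a small loss, a number 0.34 log units lower from compound 2 to compound 3 (beyond the scatter), which may not exceed the scatter. Compound 3 is accordingly estimated at 7.6, within a range of 6.9 to 8.3.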

Compound 3, negative logarithm of the half-maximal effective concentration: 7.23
Estimate against measurement, compound 3: 0.37 log units above, within the range that was stated.
By their numbers in this assay, from the lowest: compounds 1 and 3 (each within the scatter of the next); then compound 2.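

In this assay, replacing fluoro with trifluoromethyl on this aromatic carbon, para to a large group, gives a number 0.71 log units lower from compound 2 to compound 3 (beyond the scatter) and so shows that potency responds to the group placed here. This is the only single-place step shown, and it gives the size of this one change. Nothing available explains the loss.

The compounds shown leave open how a chlorine atom, a hydroxyl group or an amine would behave at this position. They also leave open whether the same change would cost as much elsewhere on the shared core.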